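The compounds below may be only part of what the source reports. "The series", "measured", "known", "first", "only" and "open" are said of these compounds alone.

Measured so far:
- compound 1, `COc1cc(C#N)ccc1OCc1nnc(-c2ccc(F)cc2)o1`: 10500 nM
- compound 2, `COc1cc(C#N)ccc1OCc1nnc(-c2ccc(Cl)cc2)o1`: 33900 nM
- compound 3, `Fc1ccc(-c2nnc(COc3ccc(-c4nnco4)cc3)o2)cc1`: 38200 nM

Compounds 1 and 2 share one core and differ only at the aryl position: chloro in place of fluoro on an aromatic carbon. In a functional assay on MDA-MB-453 cells (Homo sapiens) for cytotoxicity, read by MTT assay, with a stated time of 48 h (on this read-out lower numbers stand for stronger inhibition and higher numbers for weaker inhibition), this change gave a 3.2-fold higher number from compound 1 to compound 2 (0.51 log units; beyond the scatter), so the chloro analogue is the weaker of the pair.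

Compound 3 carries a different core from compound 1; the difference between the two cores is not broken down here. Of the three numbers, compound 3 gives the highest, but compound 2 and compound 3 lie within the scatter of each other, so no order between those two is claimed. Compound 1 stands apart from both, beyond the scatter.

Compound 4, `Clc1ccc(-c2nnc(COc3ccc(-c4nnco4)cc3)o2)cc1`, has not yet been measured. It relates to compound 3 exactly as compound 2 relates to compound 1: chloro in place of fluoro on an aromatic carbon. The place lines of the two changes are the same word for word, so this is the same change applied to the second core.

The expectation for compound 4 rests on a single prior instance of this change, compound 1 to compound 2, which moved the number by a 3.2-fold higher number from compound 1 to compound 2 (0.51 log units; beyond the scatter). For compound 4 a step of a 2.2-fold higher number from compound 3 to compound 4 (0.35 log units; beyond the scatter) in this assay is expected, because the same change on the first core gave a 3.2-fold higher number from compound 1 to compound 2 (0.51 log units; beyond the scatter). Compound 4 is therefore estimated at 85000 nM, with the plausible range spanning 30000 nM to 220000 nM. The span is wide, since one prior pair on another core is the only basis, and a number this high may be reported only as a limit.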

Compound 4, half-maximal inhibitory concentration: > 50000 nM
Compound 4: no number, only a limit (the forecaster's own chance of this, stated with the estimate: 30%); the middle value is on the limit's open side.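

In this assay compound 4 gives > 50000 nM, which is a limit of the assay and not a number. On the core of compound 3, chloro in place of fluoro gives an at least 1.3-fold higher number from compound 3 to compound 4 (0.11 log units; that floor lies within the scatter), so the result is compatible with the direction seen on the core of compound 1, but the floor of this step does not by itself establish a rise on the second core. Carrying the change across the two cores therefore has no confirmed direction on the second core and no measured size there, and the comparison of the two steps remains unresolved: the same change on two cores in this assay, a 3.2-fold higher number (0.51 log units; beyond the scatter) from compound 1 to compound 2 and an at least 1.3-fold higher number (0.11 log units; that floor lies within the scatter) from compound 3 to compound 4; the limit leaves it open whether they differ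

The compounds shown leave open how the 4-fluorophenyl position would respond to groups other than fluoro and chloro at the same place, such as an amine, a carboxylic acid or a longer alkyl chain. They also leave open which part of the difference between the core of compound 1 and the core of compound 3 bears on the read-out, and whether the change from 4-fluorophenyl to 4-chlorophenyl would follow the same direction on any further core.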